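A few compounds are considered here, and "the series" means these few. Any claim that something is new, unique, unknown or untested is made for them only; others in the source may bear on it.

Measured in an ADME assay on L1210/0 cells (Mus musculus) for cytotoxicity, with a stated time of 48 h; on this read-out higher numbers stand for weaker inhibition and lower numbers for stronger inhibition:

- Compound 1 `O=c1[nH]c(=O)n([C@H]2C[C@H](O)[C@@H](CO)O2)cc1/C=C/I` gives 63900 nM
- Compound 2 `O=C(CI)NCc1cn([C@H]2C[C@H](O)[C@@H](CO)O2)c(=O)[nH]c1=O` gives 107000 nM
- Compound 3 `CC#Cc1cn([C@H]2C[C@H](O)[C@@H](CO)O2)c(=O)[nH]c1=O` gives > 200000 nM, which is a limit and not a number

Going by these compounds, compound 3 stands at the limit of > 200000 nM in this assay, at which 1 of the 3 values shown sits, so its true value is unknown. The next structure, compound 4 `O=c1[nH]c(=O)n([C@H]2C[C@H](O)[C@@H](CO)O2)cc1/C=C/Cl`, has 2-chloroethenyl in place of prop-1-yn-1-yl on an aromatic carbon. The closest guide is compound 1, which carries 2-iodoethenyl, and an at least 3.1-fold higher number from compound 1 to compound 3 (0.49 log units; beyond the scatter). Read in reverse, that step points towards a lower number. The other measured steps, a 1.7-fold higher number from compound 1 to compound 2 (0.22 log units; within the scatter) and an at least 1.8-fold higher number from compound 2 to compound 3 (0.27 log units; that floor lies within the scatter), add little. The expected change is an at least 2.0-fold lower number from compound 3 to compound 4 (0.30 log units; that floor lies within the scatter). Compound 4 is estimated at 100000 nM, with an expected range of 40000 nM to 200000 nM.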

Compound 4, half-maximal inhibitory concentration: > 200000 nM
Compound 4: only a limit was reported; the forecaster's own chance of this, stated with the estimate: 30%; middle value at least 2.0-fold (0.30 log units) from the limit.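

Going by these compounds alone, changing only the halogen on the double-bonded chain, with chloro in place of iodo, gives an at least 3.1-fold higher number from compound 1 to compound 4 (0.49 log units; beyond the scatter) in this assay, so at this position the iodo group matters in a way the earlier compounds could not isolate. Replacing the (((iodomethyl)carbonyl)amino)methyl group with 2-chloroethenyl gives an at least 1.8-fold higher number from compound 2 to compound 4 (0.27 log units; that floor lies within the scatter), which adds little. The step from compound 3 to compound 4 cannot be read, as both values are limits: the limit of > 200000 nM in this assay, at which 2 of the 4 values shown sit.

Going by these compounds, the true value of compound 4 remains unknown. On these data alone, whether 2-bromoethenyl on the same aromatic carbon would match compound 1 or fall to the limit also stays open.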